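The source may report more compounds than this note shows. Statements on the series, on what has been measured and on what is new or still open speak of the compounds shown alone.

The shared core is carried by compound 1 `CN(C(=O)CCc1ccccc1)c1ccc2[nH]c(-c3n[nH]c4ccccc34)cc2n1` and compound 2 `CN(c1ccc2[nH]c(-c3n[nH]c4ccccc34)cc2n1)S(=O)(=O)c1ccccc1`, which differ only in the group on the nitrogen on the aromatic ring. In a functional assay on SMMC-7721 cells (Homo sapiens) for antiproliferative activity, read by MTT assay, with a stated time of 72 h (a higher number here means a weaker inhibitor, a lower number a stronger inhibitor), compound 1 gives 20900 nM, and compound 2 gives 12000 nM. The step of a 1.7-fold lower number from compound 1 to compound 2 (0.24 log units; within the scatter) therefore stays within the scatter, so compound 2 holds the lowest of the two numbers without standing apart from compound 1. Compound 3 `CN(C(=O)Nc1ccccc1)c1ccc2[nH]c(-c3n[nH]c4ccccc34)cc2n1` is the next variation at the same place: phenylcarbamoyl in place of phenylsulfonyl on a nitrogen on an aromatic ring. Within the data shown here, only one measured step bears on this change, the exchange of one substituent on that nitrogen for another, and it was small. The step is therefore expected to be a 1.3-fold higher number from compound 2 to compound 3 (0.10 log units; within the scatter), with no movement beyond the scatter in either direction. Compound 3 is estimated to give 15000 nM in this assay, within a range from 5000 nM to 45000 nM.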

Compound 3, half-maximal inhibitory concentration: 280 nM
Compound 3: the middle estimate sits 54-fold (1.73 log units) above what was measured; measured number below the stated range.
By their numbers in this assay, from the lowest: compound 3; then compounds 2 and 1 (each within the scatter of the next).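

The result shows that this nitrogen is far from indifferent to its substituent in this assay, as phenylcarbamoyl in place of phenylsulfonyl gives a 43-fold lower number from compound 2 to compound 3 (1.63 log units; beyond the scatter) and stands well apart from the earlier pair. The carbonyl alone does not account for this, since anilino in place of phenethyl on a carbonyl carbon gives a 75-fold lower number from compound 1 to compound 3 (1.87 log units; beyond the scatter) even though compound 1 also has a carbonyl on this nitrogen. No measurement is available here that explains why the anilino group changes the number so strongly.

The compounds shown leave open whether the amide hydrogen of the phenylcarbamoyl group matters, which a methylanilino group on the same carbonyl carbon would test. They also leave open how a benzylamino or cyclohexylamino group would compare there, or a fluoro or methoxy group on the phenyl ring.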